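Ethyl to propyl on the pyrazolyl sulfonyl group

The source may report more compounds than this note shows. Statements on the series, on what has been measured and on what is new or still open speak of the compounds shown alone.

Measured in an ADME assay (liver) for metabolic stability, with Liver microsome (Homo sapiens) as the target, read by LC-MS, using microsomes and NADPH, with a stated time of 5 min, at 37 degrees C; a higher number here means faster removal of the compound, a lower number slower removal:
- compound 1 `CCn1c([C@@H](C)NS(=O)(=O)C2CC2)nc2ccc(C(F)(F)F)cc21`: < 3 mL.min-1.g-1 (a limit of the assay)
- compound 2 `CCn1cc(S(=O)(=O)N[C@H](C)c2nc3ccc(C(F)(F)F)cc3n2CC)cn1`: 95 mL.min-1.g-1
- compound 3 `CCn1ncc(S(=O)(=O)N[C@H](C)c2nc3ccc(C(F)(F)F)cc3n2CC)c1C`: > 100 mL.min-1.g-1 (a limit of the assay)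

Compound 3 stands at > 100 mL.min-1.g-1, which is a limit of this assay and not a number. Compound 4 `CCCn1ncc(S(=O)(=O)N[C@H](C)c2nc3ccc(C(F)(F)F)cc3n2CC)c1C` differs from compound 3 by methyl in place of hydrogen on a saturated chain carbon, two bonds along the chain from an aromatic nitrogen, so that 1-ethyl-5-methyl-1H-pyrazol-4-yl becomes 5-methyl-1-propyl-1H-pyrazol-4-yl.

Among the compounds with values here, no measured step alters this chain. The two large steps, an at least 31-fold higher number from compound 1 to compound 2 (1.50 log units; beyond the scatter) and an at least 33-fold higher number from compound 1 to compound 3 (1.52 log units; beyond the scatter), replace cyclopropyl on a sulfonyl sulfur and so show how far the pyrazolyl groups sit from compound 1, not what one added methyl does. Within the data shown here, the nearest precedent is also a methyl in place of hydrogen, though on an aromatic carbon: an at least 1.0-fold higher number from compound 2 to compound 3 (0.02 log units; that floor lies within the scatter).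

Since compound 3 gives only a limit, no step beyond the scatter can be expected with confidence, and the expected step is a step that the limit leaves unreadable from compound 3 to compound 4. Compound 4 is expected to remain quickly removed, possibly reported as a limit. The estimate for compound 4 is 120 mL.min-1.g-1, with an expected range from 70 mL.min-1.g-1 to 200 mL.min-1.g-1.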

Compound 4, intrinsic clearance in microsomes: > 100 mL.min-1.g-1
Compound 4: no number, only a limit; the forecaster's own chance of this, stated with the estimate: 70%; the middle value lies beyond the limit too.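

Compound 4, like compound 3, gives a limit of the assay and not a number, so the step from ethyl to propyl cannot be read in this assay: the limit of > 100 mL.min-1.g-1 in this assay, at which 2 of the 4 values shown sit.

The added chain carbon therefore shows no readable effect at this position, and the comparison with the unmethylated ethyl pyrazolyl compound gives an at least 1.0-fold higher number from compound 2 to compound 4 (0.02 log units; that floor lies within the scatter). The gap to the cyclopropyl sulfonyl compound persists with the propyl chain in place, with an at least 33-fold higher number from compound 1 to compound 4 (1.52 log units; beyond the scatter).

Going by these compounds, whether propyl and ethyl differ at all in this assay stays open while both results are limits. Also open, on these data alone, is whether a 2-hydroxyethyl chain or a carboxylic acid in place of propyl would bring a pyrazolyl compound to a readable number.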